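Naphthalene for Phenyl: Growth Inhibition in Compound 4

The source may report more compounds than this note shows. Statements on the series, on what has been measured and on what is new or still open speak of the compounds shown alone.

Among the compounds with values here, in a functional assay on COLO 205 cells (Homo sapiens) for inhibition, read by sulforhodamine B assay, tested at 100 uM (on this read-out lower numbers stand for less inhibition of growth and higher numbers for more inhibition of growth at the one concentration tested), compound 3 `COc1cc(C2CC(c3ccccc3)=NN2C(C)=O)ccc1OCc1cn(Cc2ccc([N+](=O)[O-])cc2)nn1` gives 11%, the lowest of the three numbers measured so far. Compound 2 `COc1ccc(C2CC(c3ccc(OCc4cn(Cc5ccc([N+](=O)[O-])cc5)nn4)cc3)=NN2C(C)=O)cc1` gives 37% and compound 1 `CC(=O)N1N=C(c2ccc(OCc3cn(Cc4ccc([N+](=O)[O-])cc4)nn3)cc2)CC1c1ccccc1` gives 55%, both standing above compound 3 by more than the scatter. Compound 4 `COc1cc(C2CC(c3cccc4ccccc34)=NN2C(C)=O)ccc1OCc1cn(Cc2ccc([N+](=O)[O-])cc2)nn1` differs from compound 3 by naphthalen-1-yl in place of phenyl on a carbon with a double bond to nitrogen. Within the data shown here, no measured step touches this position: the only step available, a number 18 percentage points lower from compound 1 to compound 2 (beyond the scatter), alters a different ring and so offers no guide here. With nothing comparable to lean on, the change is expected to bring no step beyond the scatter, and a number 4 percentage points higher from compound 3 to compound 4 (within the scatter) is the estimated shift. Compound 4 is therefore expected to give 15%, within a range from 0% to 40%.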

Compound 4, percent growth inhibition at one concentration: 72%
Estimate against measurement, compound 4: 57 percentage points below; the measured number lies above the stated range.
By their numbers in this assay, from the lowest: compound 3; then compound 2; then compound 1; then compound 4.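

In this assay, the group on this carbon with a double bond to nitrogen clearly matters: naphthalen-1-yl in place of phenyl gives a number 61 percentage points higher from compound 3 to compound 4 (beyond the scatter). Within the data shown here, the earlier step concerned a methoxy on a different ring, so this is the first sign that this position can strongly change growth inhibition. No measurement shown here explains the step.

As far as these compounds go, it remains open whether naphthalen-2-yl or a pyridine ring at this carbon would give a similar number. From the compounds shown here alone, it is also open whether the same change would raise the numbers of compound 1 or compound 2.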